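Hydroxy for Fluoro on a Shared Core: Expected Dose

A few compounds are considered here, and "the series" means these few. Any claim that something is new, unique, unknown or untested is made for them only; others in the source may bear on it.

Measured in a functional assay on the whole organism (strain Swiss albino) with Mus musculus as the target, with a stated time of 4 h; on this read-out lower numbers stand for an effect already at smaller amounts and higher numbers for an effect only at larger amounts of compound:
Compound 1, `C=C(C)[C@@H]1CC=C(C)/C(=N/NC(=O)Nc2nnc(-c3ccc(OC)cc3)o2)C1`, gives 300 mg/kg.
Compound 2, `C=C(C)[C@@H]1CC=C(C)/C(=N/NC(=O)Nc2nnc(-c3ccc(F)cc3)o2)C1`, gives 300 mg/kg.

Compound 2 stands level with compound 1 on these numbers: the step of no change at the digits printed from compound 1 to compound 2 (within the scatter) lies within the scatter. The unmeasured compound 3, `C=C(C)[C@@H]1CC=C(C)/C(=N/NC(=O)Nc2nnc(-c3ccc(O)cc3)o2)C1`, differs from compound 2 by hydroxy in place of fluoro on an aromatic carbon.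

Going by the values given here, only one measured step bears on this change, the exchange of one group for another on the same aromatic carbon, no change at the digits printed from compound 1 to compound 2 (within the scatter), which produced no change beyond the scatter. Two compounds alone cannot establish a pattern, but nothing in them points to a shift in either direction. Compound 3 is therefore expected to show no change at the digits printed from compound 2 to compound 3 (within the scatter), no movement beyond the scatter. The estimate for compound 3 is 300 mg/kg, with a range from 150 mg/kg to 600 mg/kg.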

Compound 3, minimum effective dose: 300 mg/kg
Compound 3: middle estimate and measured number agree at the digits printed; measured number inside the range.
By their numbers in this assay, from the lowest: compounds 1, 2 and 3 (each within the scatter of the next).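

In this assay the carbon on the aromatic ring now carries hydroxy, a group with a hydrogen-bond donor, where fluoro has none, and the exchange gives no change at the digits printed from compound 2 to compound 3 (within the scatter) on the minimum effective dose. Removing the methyl from the oxygen gives the same reading, no change at the digits printed from compound 1 to compound 3 (within the scatter), so methoxy, fluoro and hydroxy at this one carbon now all lie within the scatter of each other, which two compounds could not show. Nothing at hand accounts for this level reading.

As far as these compounds go, whether an amine, a carboxylic acid or a longer chain such as butoxy on the same carbon would also leave the dose level remains open. The three compounds also leave open whether the level reading extends to changes elsewhere on the shared core, such as in the urea-like linker.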